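Cyclohexyl to hydrogen on the five-membered ring: compound 4

A few compounds are considered here, and "the series" means these few. Any claim that something is new, unique, unknown or untested is made for them only; others in the source may bear on it.

Three members of the series have been run in an ADME assay on BaF3 cells (Mus musculus) for cytotoxicity, read by MTT assay, with a stated time of 48 h; on this read-out lower numbers stand for stronger inhibition of growth and higher numbers for weaker inhibition of growth. Compound 1 `Nc1ncnc2c1c(-c1cc(C3CC3)on1)nn2C1CCCCC1` reports only the limit of the assay, > 10000 nM. Compound 2 `CC(C)n1nc(/C=N/OCc2ccccc2)c2c(N)ncnc21` likewise sits at the limit, > 10000 nM. Compound 3 `CC(C)n1nc(-c2cc(C3CCCCC3)on2)c2c(N)ncnc21` also gives only the limit, > 10000 nM. Going by the values given here, compound 3 therefore stands nowhere distinct: every value shown is a limit, and the limit of > 10000 nM in this assay, at which 3 of the 3 values shown sit, marks the position shared by all compounds measured so far. Among the compounds with values here, no step between measured compounds can be read, since none of the three differs from another in a single place.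

Compound 4 `CC(C)n1nc(-c2ccon2)c2c(N)ncnc21` differs from compound 3 by hydrogen in place of cyclohexyl on an aromatic carbon. The cyclohexyl leaves and a hydrogen atom enters at the aromatic carbon of the five-membered aromatic ring with 1 nitrogen and 1 oxygen. With nothing measured but limits, no direction can be drawn in this assay. The step expected for compound 4, a step that the limit leaves unreadable from compound 3 to compound 4, is none beyond the scatter. Compound 4 is expected to give 20000 nM, within 5000 nM to 100000 nM, and most likely the assay will again report only its limit.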

Compound 4, concentration for 50% growth inhibition: > 10000 nM
Compound 4 was reported as a limit; the forecaster's own chance of this, stated with the estimate: 85%; the middle value does not contradict the limit.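

The step between compound 3 and compound 4 cannot be read, as both are reported only as limits in this assay. The compounds shown leave open whether any change on the shared core brings a readable value in this assay, with all of them still at one position: the limit of > 10000 nM in this assay, at which 4 of the 4 values shown sit.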